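This account rests on a few compounds, and the source may have more. Where it says the series, first, only, none or still open, it means among the compounds named here.

Measured in a functional assay for inhibition, with Homo sapiens as the target; a higher number here means that more compound is needed for the effect, a lower number that less compound is needed:
- compound 1 `CCC(=O)Nc1ccc(C2=NNC(=O)CC2)cc1`: 0.64 ug/mL
- compound 2 `CCC(Cl)C(=O)Nc1ccc(C2=NNC(=O)CC2)cc1`: 1.47 ug/mL
- compound 3 `CC(C)(CCl)C(=O)Nc1ccc(C2=NNC(=O)CC2)cc1`: 11.4 ug/mL

Compound 3 has the highest number of the three. The next step leads to compound 4 `C=CCNCC(=O)Nc1ccc(C2=NNC(=O)CC2)cc1` and is (allylamino)methyl in place of 1-(chloromethyl)-1-methylethyl on a carbonyl carbon, with (allylamino)methyl in place of 1-(chloromethyl)-1-methylethyl on a carbonyl carbon. Three measured steps change the group at this place: an 18-fold higher number from compound 1 to compound 3 (1.25 log units; beyond the scatter), a 7.8-fold higher number from compound 2 to compound 3 (0.89 log units; beyond the scatter) and a 2.3-fold higher number from compound 1 to compound 2 (0.36 log units; beyond the scatter). Among the compounds with values here, none of the measured compounds carries (allylamino)methyl, so these steps are only indirect guidance. Both measured steps away from compound 3 would lead to lower numbers, so a modest fall in this assay is expected, a 4.6-fold lower number from compound 3 to compound 4 (0.66 log units; beyond the scatter). Compound 4 is estimated at 2.5 ug/mL, with an expected range of 0.5 ug/mL to 11 ug/mL.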

Compound 4, half-maximal effective concentration: about 21.5 ug/mL
Compound 4: middle estimate off by 8.6-fold (0.93 log units), on the low side; measured number above the stated range.
By their numbers in this assay, from the lowest: compound 1; then compound 2; then compounds 3 and 4 (each within the scatter of the next).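

In this assay, (allylamino)methyl is the only nitrogen-bearing group shown on this carbonyl carbon, and a 1.9-fold higher number from compound 3 to compound 4 (0.28 log units; within the scatter) does not separate it from 1-(chloromethyl)-1-methylethyl. The gaps to the groups with fewer heavy atoms are wide, with a 15-fold higher number from compound 2 to compound 4 (1.17 log units; beyond the scatter) and a 34-fold higher number from compound 1 to compound 4 (1.53 log units; beyond the scatter), so a high number at this place does not depend on chlorine, and ethyl keeps the lowest number of the series. No measured evidence bears on the cause of these steps.

As far as these compounds go, whether a plain aminomethyl group, a tertiary amine or a carboxylic acid would come closer to ethyl remains open. Also open, from the compounds shown here alone, is whether the allyl part or the amine nitrogen sets the number of compound 4.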